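Chlorochromone dithiocarbamates: pyrrolidine to morpholine swap

This account rests on a few compounds, and the source may have more. Where it says the series, first, only, none or still open, it means among the compounds named here.

Measured so far:
compound 1 `O=c1cc(CSC(=S)N2CCCC2)oc2cc(Cl)ccc12` gives > 25000 nM; this is a limit of the assay, not a number.
compound 2 `O=c1cc(CSC(=S)N2CCOCC2)oc2cc(Cl)ccc12` gives > 25000 nM; likewise a limit of the assay.
compound 3 `O=c1c(Cl)c(CSC(=S)N2CCCC2)oc2ccccc12` gives 2300 nM in a functional assay on MCF7 cells (Homo sapiens) for antiproliferative activity, read by MTT assay, with a stated time of 72 h; on this read-out lower numbers stand for stronger inhibition and higher numbers for weaker inhibition.

Compound 1 and compound 3 share the same atoms joined differently; the difference between the two cores is not broken down here. Among the measured compounds shown here, compound 3 carries the only numeric value in this assay, the other two values being limits, as the evidence notes (the limit of > 25000 nM in this assay, at which 2 of the 3 values shown sit).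

The change from compound 1 to compound 2 is morpholin-4-yl in place of pyrrolidin-1-yl on a thiocarbonyl carbon. Its size in this assay, a step that the two limits leave unreadable from compound 1 to compound 2, cannot be read because both ends sit at the limit.

Compound 4 `O=c1c(Cl)c(CSC(=S)N2CCOCC2)oc2ccccc12` is not yet measured. It differs from compound 3 by morpholin-4-yl in place of pyrrolidin-1-yl on a thiocarbonyl carbon, the same kind of change, at the same kind of place. Nothing measured sets the direction or size of this step. The step from compound 3 to compound 4 is therefore expected to be small, near a 1.7-fold higher number from compound 3 to compound 4 (0.24 log units; within the scatter), with wide uncertainty. Compound 4 is expected to give about 4000 nM in this assay, within 1000 nM to 25000 nM.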

Compound 4, half-maximal inhibitory concentration: 11100 nM
For compound 4 the middle estimate is 2.8-fold (0.44 log units) below the measured one; measured number inside the range.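

In this assay, morpholin-4-yl in place of pyrrolidin-1-yl on a thiocarbonyl carbon gives, on the core of compound 3, a 4.8-fold higher number from compound 3 to compound 4 (0.68 log units; beyond the scatter), so on this core the change weakens inhibition by a modest step. On the core of compound 1 the same change cannot be read, because both ends of that pair are limits of the assay and not numbers: the limit of > 25000 nM in this assay, at which 2 of the 4 values shown sit.

The series therefore holds one readable step, which shows nothing about whether its direction or size carries from one core to the other, though the pair at the limit does not contradict it either.

Open, going by these compounds, is how a piperidin-1-yl group or an open-chain diethylamino group would compare with pyrrolidin-1-yl on the thiocarbonyl carbon of the core of compound 3. Also open, on these data alone, is whether any such group brings the core of compound 1 to a numeric value in this assay.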